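Swapping an aminophenyl for methyl on a weak cytotoxic amide

The source may report more compounds than this note shows. Statements on the series, on what has been measured and on what is new or still open speak of the compounds shown alone.

Measured compounds:
compound 1, `Nc1ccc(Nc2c(C(=O)NCc3ccc(F)cc3)nc(Br)c3cccnc23)cc1`, 10000 nM
compound 2, `CN(C)c1ccc(CNC(=O)c2nc(Br)c3cccnc3c2N[C@H]2CC[C@H](N)CC2)cc1`, "not determined" (no result reported)

Among the measured compounds shown here, only one number is available here. In a functional assay on HCT-116 cells (Homo sapiens) for cytotoxicity, read by MTT assay, with a stated time of 72 h (a lower number here means a stronger inhibitor, a higher number a weaker inhibitor), compound 1 gives 10000 nM, which is a weak result, and compound 2 gives "not determined" (no result reported), so nothing can be said about how the two relate. For the measured compounds named here, with a single number, compound 1 simply stands alone; there is no second measured compound to rank it against.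

Compound 3, `CNc1c(C(=O)NCc2ccc(F)cc2)nc(Br)c2cccnc12`, shares the core of compound 1 and differs only at one spot: methyl in place of 4-aminophenyl on a nitrogen on an aromatic ring. The shift is from (4-aminophenyl)amino to methylamino, so a six-membered aromatic ring leaves and a single carbon enters.

Going by the values given here, no step between measured compounds exists to guide the direction. The step of a 1.5-fold higher number from compound 1 to compound 3 (0.18 log units; within the scatter) is expected to be small, staying within the usual scatter. Compound 3 is therefore estimated at 15000 nM, with a range from 3000 nM to 60000 nM.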

Compound 3, half-maximal inhibitory concentration: > 20000 nM
Compound 3: no number, only a limit (the forecaster's own chance of this, stated with the estimate: 40%); middle value at least 1.3-fold (0.12 log units) away from the limit.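

Putting methyl in place of 4-aminophenyl on a nitrogen on an aromatic ring gives, in this assay, an at least 2.0-fold higher number from compound 1 to compound 3 (0.30 log units; that floor lies within the scatter). Compound 3 carries a limit of the assay and not a number: the limit of > 20000 nM in this assay, at which 1 of the 3 values shown sits.

So removing the six-membered aromatic ring at this position brings no gain on the already weak result of compound 1, although the floor of the step alone does not establish a real loss.

The compounds shown leave open whether the ring itself or the amine it carries matters at this nitrogen. A plain phenyl, with no amine, would separate the two, and a longer chain such as propyl would show whether a simple carbon group larger than methyl gives a measurable number in this assay.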